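The source may hold more compounds than are shown below. What is called first, only, known or untested is meant among the compounds shown, and "the series" means these compounds.

Measured compounds in an ADME assay on Huh-7 cells (Homo sapiens) for cytotoxicity, with a stated time of 3 days; on this read-out lower numbers stand for higher toxicity in this test and higher numbers for lower toxicity in this test:
- compound 1 `CCOc1ccccc1NC(=O)c1c(NCCO)cc(-c2ccccc2)oc1=O`; compound 1 gives > 20000 nM, a limit of the assay
- compound 2 `O=C(Nc1ccc(Br)cc1)c1c(NCCO)cc(-c2ccc(Br)cc2)oc1=O`; compound 2 gives > 20000 nM, a limit of the assay
- compound 3 `CCOc1ccccc1NC(=O)c1c(NCCO)cc(-c2ccc(Br)cc2)oc1=O`; compound 3 gives > 20000 nM, a limit of the assay

Compound 3 therefore stands only at a limit, together with the two other measured compounds: the limit of > 20000 nM in this assay, at which 3 of the 3 values shown sit. Its two single-change neighbours say nothing about size, since a step that the two limits leave unreadable from compound 1 to compound 3 and a step that the two limits leave unreadable from compound 2 to compound 3 are both unreadable between two limits.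

The next compound, compound 4 `CCOc1ccccc1NC(=O)c1c(NCCO)cc(-c2cccs2)oc1=O`, differs from compound 3 in one place: thiophen-2-yl in place of 4-bromophenyl on an aromatic carbon. For the measured compounds named here, no measured step touches this position of the shared core, so the only guidance is that every measured compound, compound 1, compound 2 and compound 3 alike, sits at the same limit. A step in this assay beyond the scatter is accordingly not expected; the expected outcome for compound 4 is again a value at or past the limit, a step that the limit leaves unreadable from compound 3 to compound 4 in size, with no direction that the data could support. The estimated value for compound 4 in this assay is 25000 nM, between 12000 nM and 60000 nM, with a high chance that only a limit is reported.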

Compound 4, half-maximal cytotoxic concentration: 10000 nM
Compound 4: middle estimate off by 2.5-fold (0.40 log units), on the high side; measured number below the stated range.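

In this assay compound 4 gives 10000 nM, so a change on the aromatic carbon next to the ring oxygen yields a measured number rather than a limit. Thiophen-2-yl in place of 4-bromophenyl gives an at least 2.0-fold lower number from compound 3 to compound 4 (0.30 log units; that floor lies within the scatter), and thiophen-2-yl in place of phenyl gives an at least 2.0-fold lower number from compound 1 to compound 4 (0.30 log units; that floor lies within the scatter); each is only a floor, and since both floors lie within the scatter, neither step is shown to exceed it, although the true sizes may be larger. Compound 4 is the only compound in the series with a measured number, and the other three stay at the limit: the limit of > 20000 nM in this assay, at which 3 of the 4 values shown sit.

On these data alone, it remains open whether a furan-2-yl, thiophen-3-yl or pyridine ring on this carbon would also give a measured number, which would help show whether the result is specific to thiophen-2-yl. As far as these compounds go, it is also open whether thiophen-2-yl would give a similar number with 4-bromophenyl in place of 2-ethoxyphenyl on the amide nitrogen, or with a longer chain in place of the (2-hydroxyethyl)amino group.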